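A few compounds are considered here, and "the series" means these few. Any claim that something is new, unique, unknown or untested is made for them only; others in the source may bear on it.

In a functional assay on LOX IMVI cells (Homo sapiens) for cytotoxicity, read by sulforhodamine B assay, with a stated time of 48 h, tested at 100 uM (on this read-out lower numbers stand for a stronger effect and higher numbers for a weaker effect at the one concentration tested), compound 2 `COc1ccc(C(=O)/C=C/c2cc(-c3cc(OC)c(OC)c(OC)c3)n[nH]2)cc1OC` gives -79%. Among the compounds with values here, the only other compound measured, compound 1 `COc1cc(-c2cc(/C=C/C(=O)c3ccc(N)cc3)[nH]n2)cc(OC)c1OC`, gives -82% in this assay, and the step of a number 3 percentage points higher from compound 1 to compound 2 (within the scatter) shows that the two numbers lie within the usual scatter of each other. Compound 3 `COc1cc(-c2cc(/C=C/C(=O)c3ccc(F)c(F)c3)[nH]n2)cc(OC)c1OC` has not yet been measured in this assay. It differs from compound 2 in one place: 3,4-difluorophenyl in place of 3,4-dimethoxyphenyl on a carbonyl carbon. Within the data shown here, the one measured step that bears on this change is the swap of the aryl group on the same carbonyl carbon, a number 3 percentage points higher from compound 1 to compound 2 (within the scatter), which left the read-out essentially unchanged. On that basis compound 3 is expected to show a step of a number 1 percentage points higher from compound 2 to compound 3 (within the scatter) in this assay, that is, no movement beyond the scatter in either direction. Compound 3 is therefore estimated at -78% in this assay, with a likely range from -95% to -55%.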

Compound 3, a percentage reported as activity, at one concentration (the size of the read-out at that concentration, not a potency): -86%
Compound 3: the middle estimate sits 8 percentage points above what was measured; measured number inside the range.
By their numbers in this assay, from the lowest: compounds 3, 1 and 2 (each within the scatter of the next).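

In this assay, replacing the 3,4-dimethoxyphenyl with 3,4-difluorophenyl gives a number 7 percentage points lower from compound 2 to compound 3 (within the scatter), and replacing the 4-aminophenyl with the same group gives a number 4 percentage points lower from compound 1 to compound 3 (within the scatter). The place on a carbonyl carbon beside the double-bonded chain carbon thus now holds an aryl group with 8 heavy atoms and 0 hydrogen-bond acceptors, as well as one with 10 heavy atoms and 2 hydrogen-bond acceptors, and the three aryl groups are not separated by this read-out. Nothing available explains why these groups are not separated.

As far as these compounds go, it remains open whether a group without an aromatic ring, such as cyclohexyl or a longer alkyl chain, or a phenyl carrying a carboxylic acid, would stay level with these three. From the compounds shown here alone, since the read-out comes from a single concentration, it also remains open whether the three compounds differ in potency.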